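The compounds below may be only part of what the source reports. "The series", "measured", "known", "first", "only" and "open" are said of these compounds alone.

In a functional assay on MCF7 cells (Homo sapiens) for antiproliferative activity, read by MTT assay, with a stated time of 72 h (on this read-out higher numbers stand for weaker inhibition and lower numbers for stronger inhibition), compound 1 `COc1ccc(-c2ncnn2-c2cc(OC)c(OC)c(OC)c2)cc1` gives 360 nM. Compound 2 `COc1cc(-n2ncnc2-c2ccc(Cl)cc2)cc(OC)c1OC` reads > 10000 nM, which is a limit of the assay. Within the data shown here, compound 3 `CCOc1ccc(-c2ncnn2-c2cc(OC)c(OC)c(OC)c2)cc1` gives 50 nM, the lowest number so far.

Compound 4 `COc1cc(-n2ncnc2-c2ccc(OC(C)C)cc2)cc(OC)c1OC` differs from compound 3 by methyl in place of hydrogen on a saturated chain carbon bound to an oxygen on an aromatic ring and a saturated chain carbon, ethoxy to isopropoxy. Among the measured compounds shown here, the closest precedent is a 7.2-fold lower number from compound 1 to compound 3 (0.86 log units; beyond the scatter), also a methyl in place of hydrogen, but on a carbon without a further chain carbon. The large steps of an at least 27-fold higher number from compound 1 to compound 2 (1.44 log units; beyond the scatter) and an at least 200-fold lower number from compound 2 to compound 3 (2.30 log units; beyond the scatter) involve chloro and rest on a limit, so they bear little on this change. With one loose precedent, no step beyond the scatter is expected in this assay: the estimated step is a 1.6-fold higher number from compound 3 to compound 4 (0.20 log units; within the scatter). Compound 4 is expected at 80 nM, within an estimated range of 20 nM to 400 nM.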

Compound 4, half-maximal inhibitory concentration: 610 nM
Beside the measured number, compound 4's estimate is 7.6-fold (0.88 log units) below it, and the stated range ends below it.
By their numbers in this assay, from the lowest: compound 3; then compounds 1 and 4 (each within the scatter of the next). At a limit, above all of these: compound 2.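

In this assay, a further methyl on the saturated chain carbon bound to the oxygen runs against the earlier methyl step: a 12-fold higher number from compound 3 to compound 4 (1.09 log units; beyond the scatter), as opposed to a 7.2-fold lower number from compound 1 to compound 3 (0.86 log units; beyond the scatter). Methoxy and isopropoxy stay within the scatter of each other, a 1.7-fold higher number from compound 1 to compound 4 (0.23 log units; within the scatter), so of these three groups only ethoxy stands apart. Isopropoxy in place of chloro gives an at least 16-fold lower number from compound 2 to compound 4 (1.21 log units; beyond the scatter), a step that rests on a limit: the limit of > 10000 nM in this assay, at which 1 of the 4 values shown sits.

The compounds shown leave open how a straight propoxy chain would read here, and so whether the step from ethoxy to isopropoxy belongs to branching or to chain size.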